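Swapping the side chain of compound 1 for an azetidine

This account rests on a few compounds, and the source may have more. Where it says the series, first, only, none or still open, it means among the compounds named here.

For the measured compounds named here, in a functional assay on MDA-MB-231 cells (Homo sapiens) for inhibition, read by sulforhodamine B assay, with a stated time of 48 h (on this read-out higher numbers stand for weaker inhibition of growth and lower numbers for stronger inhibition of growth), compound 1 `COc1ccc2c(c1)NC(=O)CN2c1nc(COCCCC(=O)NO)nc2ccccc12` gives 1020 nM, the highest of the three numbers measured so far and so the weakest growth inhibition. Compound 4 `COc1ccc2c(c1)NC(=O)CN2c1nc(N2CC(OC)C2)nc2ccccc12` differs from it in one place: 3-methoxyazetidin-1-yl in place of (3-(hydroxycarbamoyl)propoxy)methyl on an aromatic carbon. Two other compounds also lose that chain at the same aromatic carbon. Compound 2 `COc1ccc2c(c1)NC(=O)CN2c1nc(NC2CC2)nc2ccccc12` gives 10.5 nM, and compound 3 `CCCCNc1nc(N2CC(=O)Nc3cc(OC)ccc32)c2ccccc2n1` gives 7.19 nM. Both steps were large: a 97-fold lower number from compound 1 to compound 2 (1.99 log units; beyond the scatter), and a 140-fold lower number from compound 1 to compound 3 (2.15 log units; beyond the scatter). Exchanging the cyclopropyl for butyl changed little: a 1.5-fold lower number from compound 2 to compound 3 (0.16 log units; within the scatter). Going by the values given here, no measured compound carries the 3-methoxyazetidin-1-yl group, so the range stays wide. A similarly large drop is expected, an estimated 68-fold lower number from compound 1 to compound 4 (1.83 log units; beyond the scatter). Compound 4 is estimated at 15 nM, with an expected range of 4 nM to 60 nM.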

Compound 4, concentration for 50% growth inhibition: 53.1 nM
Compound 4: middle estimate off by 3.5-fold (0.55 log units), on the low side, and the stated range covers the measured number.
By their numbers in this assay, from the lowest: compounds 3 and 2 (each within the scatter of the next); then compound 4; then compound 1.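

At the aromatic carbon between two ring nitrogen atoms, the 3-methoxyazetidin-1-yl group still brings a large gain over the (3-(hydroxycarbamoyl)propoxy)methyl chain, with a 19-fold lower number from compound 1 to compound 4 (1.28 log units; beyond the scatter) in this assay. Not every replacement there performs alike, however: a 5.1-fold higher number from compound 2 to compound 4 (0.70 log units; beyond the scatter) and a 7.4-fold higher number from compound 3 to compound 4 (0.87 log units; beyond the scatter), so the close match between cyclopropylamino and butylamino does not extend to this ring. Nothing available explains these gaps. Open, on these data alone, is whether an azetidine without the methoxy, or a larger ring such as pyrrolidine or morpholine, would sit nearer compound 2 or compound 4.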